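Swapping the Nitro-Bearing Ring for a Second Carboxyphenyl

The source may report more compounds than this note shows. Statements on the series, on what has been measured and on what is new or still open speak of the compounds shown alone.

Measured compounds:
compound 1, `O=C(O)c1ccc(C(=O)/C(=C\c2ccc(F)c([N+](=O)[O-])c2)SCc2ccc(Cl)cc2)cc1`, 50000 nM
compound 2, `O=C(O)c1ccc(C(=O)/C(=C\c2ccc(Cl)c([N+](=O)[O-])c2)SCc2ccc(C(F)(F)F)cc2)cc1`, 1000 nM
compound 3, `O=C(O)c1ccc(C(=O)/C(=C\c2ccc(Cl)c([N+](=O)[O-])c2)SCc2ccc(Cl)cc2)cc1`, 1000 nM

All three share one core and were tested in a functional assay on DU-145 cells (Homo sapiens) for inhibition, read by trypan blue exclusion, with a stated time of 96 h; a lower number here means a stronger inhibitor of growth, a higher number a weaker inhibitor of growth. Within the data shown here, compound 3 stands level with compound 2, and the two together give the lowest numbers of the three; the one step that separates them, no change at the digits printed from compound 2 to compound 3 (within the scatter), lies within the scatter. Compound 1 is far behind, as a 50-fold lower number from compound 1 to compound 3 (1.70 log units; beyond the scatter) shows, a large step that comes from a single change, chloro in place of fluoro on an aromatic carbon.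

Compound 4 is `O=C(O)c1ccc(/C=C(/SCc2ccc(Cl)cc2)C(=O)c2ccc(C(=O)O)cc2)cc1`. Compared with compound 3, the difference is 4-carboxyphenyl in place of 4-chloro-3-nitrophenyl on a double-bonded chain carbon bound to a double-bonded chain carbon. Among the measured compounds shown here, no measured step touches this change: both earlier steps altered one substituent on a ring, whereas here the whole 4-chloro-3-nitrophenyl is exchanged for 4-carboxyphenyl. The step from compound 1 to compound 3 does show that this part of the molecule can move the number a great deal, and a change this complete is expected to weaken growth inhibition rather than improve it. Compound 4 is therefore expected to give a higher number in this assay, an estimated step of an 8.0-fold higher number from compound 3 to compound 4 (0.90 log units; beyond the scatter). The estimate for compound 4 is 8000 nM, with a range from 1500 nM to 50000 nM.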

Compound 4, concentration for 50% growth inhibition: > 100000 nM
Compound 4: a limit, no number; the forecaster's own chance of this, stated with the estimate: 15%; at least 12-fold (1.09 log units) between middle value and limit.
By their numbers in this assay, from the lowest: compounds 2 and 3 (each within the scatter of the next); then compound 1. At a limit, above all of these: compound 4.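

Compound 4 carries no number in this assay, only a limit of the assay: the limit of > 100000 nM in this assay, at which 1 of the 4 values shown sits. The earlier steps shown here changed a single substituent on this ring, whereas exchanging the whole 4-chloro-3-nitrophenyl for 4-carboxyphenyl on a double-bonded chain carbon bound to a double-bonded chain carbon gives an at least 100-fold higher number from compound 3 to compound 4 (2.00 log units; beyond the scatter), so the growth inhibition seen with the chloro and nitro ring does not carry over to this replacement. The matching exchange from the 4-fluoro-3-nitrophenyl ring gives an at least 2.0-fold higher number from compound 1 to compound 4 (0.30 log units; that floor lies within the scatter), and because that figure is only a floor, this pair shows no firm gap, even though the step from the chloro compound is large.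

This single exchange removes the chloro and the nitro and brings in a carboxylic acid all at once, so the compounds shown cannot tell whether the loss of the old substituents or the arrival of the new acid accounts for the result. A plain phenyl ring at this place, or a methyl ester in place of the new carboxylic acid, would begin to separate those two possibilities.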